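This account rests on a few compounds, and the source may have more. Where it says the series, first, only, none or still open, it means among the compounds named here.

Compound 2 `COCNc1n[n+]([O-])c2ccccc2[n+]1[O-]`: 4270 nM
Compound 1 `[O-][n+]1nc(NCOCc2ccc(C(F)(F)F)cc2)[n+]([O-])c2ccccc21`: 9310 nM

In a functional assay on PC-3 cells (Homo sapiens) for cytotoxicity, read by MTT assay, with a stated time of 72 h (a lower number here means a stronger inhibitor, a higher number a weaker inhibitor), compound 2 stands at the lower of the two measured numbers, while compound 1 gives 9310 nM, a gap beyond the usual scatter. Compound 3 `CCCCCCCOCNc1n[n+]([O-])c2ccccc2[n+]1[O-]` differs from compound 2 by hexyl in place of hydrogen on a saturated chain carbon bound to an oxygen on a saturated carbon. For the measured compounds named here, no measured step of this kind is available here, so its size is uncertain; the only hint is that compound 1, which carries a larger group, is the weaker inhibitor. A modest step toward weaker inhibition is therefore expected, a 1.5-fold higher number from compound 2 to compound 3 (0.18 log units; within the scatter). Compound 3 is estimated at 6500 nM, with a range from 2200 nM to 19000 nM.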

Compound 3, half-maximal inhibitory concentration: 390 nM
Compound 3: the middle estimate sits 17-fold (1.22 log units) above what was measured, outside the stated range (below it).
By their numbers in this assay, from the lowest: compound 3; then compound 2; then compound 1.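

In this assay, the saturated chain carbon bound to an oxygen on a saturated carbon turns out to be a sensitive position: hexyl in place of hydrogen gives an 11-fold lower number from compound 2 to compound 3 (1.04 log units; beyond the scatter), a large move toward stronger inhibition. For the compounds shown here, the earlier compounds offered no single-change step at this position, so this is the first direct sign that adding a plain carbon chain here can strengthen inhibition. No supporting measurement explains the size of this step. From the compounds shown here alone, one step cannot define a trend, so the effects of a shorter chain such as ethyl, a longer chain such as decyl, or an amine at the end of the hexyl chain remain open.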